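This account rests on a few compounds, and the source may have more. Where it says the series, first, only, none or still open, it means among the compounds named here.

In a physicochemical assay for solubility, at pH 7.4 (on this read-out lower numbers stand for lower solubility and higher numbers for higher solubility), compound 1 (`NS(=O)(=O)c1ccc(S(=O)(=O)CC(O)CO)cc1`) reads 14900 ug/mL and compound 3 (`NS(=O)(=O)c1ccc(SCCO)c(C(=O)O)c1`) reads 9300 ug/mL while compound 2 (`NS(=O)(=O)c1ccc(S(=O)(=O)CCCO)c([N+](=O)[O-])c1`) reads 800 ug/mL as the lowest of the three, with both others higher by more than the usual scatter. Compound 4 (`COC(=O)c1cc(S(N)(=O)=O)ccc1S(=O)(=O)CCCO`) has not yet been measured. It differs from compound 2 by methoxycarbonyl in place of nitro on an aromatic carbon. Among the measured compounds shown here, no measured pair here differs in one place, so the expectation rests on this structural change alone. In this assay no shift beyond the scatter is expected, with the estimated 1.2-fold lower number from compound 2 to compound 4 (0.09 log units; within the scatter) staying within it. For compound 4 the expected value is 650 ug/mL with an estimated span from 220 ug/mL to 1900 ug/mL as its range.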

Compound 4, solubility: 14000 ug/mL
For compound 4 the middle estimate is 22-fold (1.33 log units) below the measured one; measured number outside the range, above it.
By their numbers in this assay, from the lowest: compound 2; then compounds 3, 4 and 1 (each within the scatter of the next).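

In this assay, among the compounds shown here, methoxycarbonyl in place of nitro, on an aromatic carbon ortho to a group of 7 heavy atoms and meta to a sulfamoyl group, gives an 18-fold higher number from compound 2 to compound 4 (1.24 log units; beyond the scatter) and is the first single-place comparison, showing that the read-out is highly sensitive to the group at this position. The two groups have the same hydrogen-bond donor and acceptor counts and no net charge, and they differ by one heavy atom, yet the step is large. Nothing at hand explains its size.

Going by these compounds, whether an amine, a nitrile or an amide on this aromatic carbon would read nearer compound 2 or compound 4 remains open. So does whether the step would persist with a longer chain on the sulfonyl group.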